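Redrawing two stereocentres of compound 1

This account rests on a few compounds, and the source may have more. Where it says the series, first, only, none or still open, it means among the compounds named here.

In a functional assay on HeLa cells (Homo sapiens) for cytotoxicity, read by MTT assay (a higher number here means a weaker inhibitor, a lower number a stronger inhibitor), compound 1 (`COC(=O)C[C@@H]1C[C@@H](O)[C@H](C)[C@H](c2ccccc2)N1`) gives 6500 nM and compound 2 (`COC(=O)C[C@H]1C[C@@H](O)[C@@H](C)[C@@H](c2ccc(OC)cc2)N1`) gives 11500 nM and these two values lie within the usual scatter of each other. Compound 3 (`COC(=O)C[C@H]1C[C@@H](O)[C@H](C)[C@@H](c2ccccc2)N1`) has the same atoms and bonds as compound 1 and differs only in configuration as drawn (the two compounds have the same atoms and bonds and differ only in configuration as drawn: 2 of 4 stereo elements differ; a stereocentre at a saturated ring carbon is drawn S in compound 1 and R in compound 3; a stereocentre at a saturated ring carbon is drawn R in compound 1 and S in compound 3). Within the data shown here, no measured pair shows what such a change does, so the expectation rests on little. The expected 1.2-fold higher number from compound 1 to compound 3 (0.09 log units; within the scatter) stays within the scatter, with neither direction favoured. For compound 3 the estimated value is 8000 nM (2500 nM to 25000 nM).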

Compound 3, half-maximal inhibitory concentration: 35200 nM
Compound 3: the middle estimate sits 4.4-fold (0.64 log units) below what was measured; measured number outside the range, above it.
By their numbers in this assay, from the lowest: compounds 1 and 2 (each within the scatter of the next); then compound 3.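

In this assay, redrawing two stereocentres at saturated ring carbons is enough to weaken the reading, with a 5.4-fold higher number from compound 1 to compound 3 (0.73 log units; beyond the scatter). The pair of compound 1 and compound 2 could not show this, since those two differ in more than one place and their values lie within the scatter. This step can be assigned to configuration alone because of one structural fact: the fact that compounds 1 and 3 differ only in the configuration as drawn

Which of the two redrawn stereocentres carries the shift stays open, since they changed together. Also open, from the compounds shown here alone, is whether it persists with a carboxylic acid in place of the methyl ester.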